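Aryl ring swap at the para position of the phenethyl group

A few compounds are considered here, and "the series" means these few. Any claim that something is new, unique, unknown or untested is made for them only; others in the source may bear on it.

Measured so far:
compound 1 `CCC(C)(C)Cc1c[nH]c(CCc2ccc(-n3cccn3)cc2)n1` — 113 nM
compound 2 `CCC(C)(C)Cc1c[nH]c(CCc2ccc(-n3ccnn3)cc2)n1` — 111 nM

Both values come from a functional assay on HEK293 cells for agonist activity at Bombesin receptor subtype-3 (Mus musculus), read by luminescence and calcium flux, with a stated time of 10 min; a higher number here means that more compound is needed for the effect, a lower number that less compound is needed. Compound 2 and compound 1 sit together, the step of a 1.0-fold lower number from compound 1 to compound 2 (0.01 log units; within the scatter) being within the scatter, so neither can be called the more potent.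

Compound 3 `CCC(C)(C)Cc1c[nH]c(CCc2ccc(-c3cccnc3)cc2)n1` is not yet measured. The change is pyridin-3-yl in place of 1H-1,2,3-triazol-1-yl on an aromatic carbon. Among the measured compounds shown here, the only measured step exchanged one five-membered ring for another and stayed flat; it bears only loosely on a move to a six-membered, carbon-linked ring. Little shift beyond the scatter is expected, a 1.1-fold higher number from compound 2 to compound 3 (0.03 log units; within the scatter), giving an estimated 120 nM for compound 3 in this assay, with a range of 40 nM to 400 nM.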

Compound 3, half-maximal effective concentration: 97 nM
Compound 3: the middle estimate sits 1.2-fold (0.09 log units) above what was measured; the range from low to high includes it.
By their numbers in this assay, from the lowest: compounds 3, 2 and 1 (each within the scatter of the next).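

At this place, on an aromatic carbon para to a large group, a six-membered aromatic ring serves as well as the five-membered ones. In this assay pyridin-3-yl in place of 1H-1,2,3-triazol-1-yl gives a 1.1-fold lower number from compound 2 to compound 3 (0.06 log units; within the scatter), and pyridin-3-yl in place of 1H-pyrazol-1-yl gives a 1.2-fold lower number from compound 1 to compound 3 (0.07 log units; within the scatter). Ring size and the number of ring hetero atoms both change without any step beyond the scatter, and no measurement at hand offers a reason for this flatness.

From the compounds shown here alone, whether any group here moves the number beyond the scatter remains open, for example a plain phenyl ring, an amine or a carboxylic acid. A phenyl ring would also test whether a ring nitrogen is needed at all.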